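Lengthening the Amino Side Chain on a Shared Core

This account rests on a few compounds, and the source may have more. Where it says the series, first, only, none or still open, it means among the compounds named here.

Compound 1 `CCCCNc1nc(SCC)nc2ncccc12` gives 9200 nM in a functional assay on MDA-MB-231 cells (Homo sapiens) for cytotoxicity, read by neutral red uptake, with a stated time of 72 h; on this read-out lower numbers stand for stronger inhibition and higher numbers for weaker inhibition.
Compound 2 `CCCCCNc1nc(SCC)nc2ncccc12` gives 1300 nM in this assay.
Compound 3 `CCCCNc1nc(SC(C)C)nc2ncccc12` gives 15700 nM in this assay.

Among these three, compound 3 has the highest number; its gap to compound 1 is within the scatter of repeated measurements, while compound 2 sits far below it. Compound 4 `CCCCCNc1nc(SC(C)C)nc2ncccc12` has not yet been measured. It differs from compound 3 by methyl in place of hydrogen on a saturated chain carbon, four bonds along the chain from a nitrogen on an aromatic ring. One measured step matches this change exactly, made on compound 1 instead: a 7.1-fold lower number from compound 1 to compound 2 (0.85 log units; beyond the scatter). The other step, a 1.7-fold higher number from compound 1 to compound 3 (0.23 log units; within the scatter), concerns the chain carbon bound to a sulfur and changed little. Because a 7.1-fold lower number from compound 1 to compound 2 (0.85 log units; beyond the scatter) was clearly beyond the scatter, the same chain lengthening on compound 3 is expected to give a similar move, a 7.1-fold lower number from compound 3 to compound 4 (0.85 log units; beyond the scatter), toward a lower number. The estimate for compound 4 is therefore 2200 nM, with a likely range from 900 nM to 5500 nM.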

Compound 4, half-maximal inhibitory concentration: 5600 nM
For compound 4 the middle estimate is 2.5-fold (0.41 log units) below the measured one; the measured number lies above the stated range.
By their numbers in this assay, from the lowest: compound 2; then compounds 4, 1 and 3 (each within the scatter of the next, the first and the last beyond it).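

In this assay, the methyl in place of hydrogen, four bonds along the chain from a nitrogen on an aromatic ring, still gives a lower number on a second core, a 2.8-fold lower number from compound 3 to compound 4 (0.45 log units; beyond the scatter), so the direction seen on compound 1 is repeated. The size of this step cannot be told apart on the two cores: the same change on two cores in this assay, a 7.1-fold lower number (0.85 log units; beyond the scatter) from compound 1 to compound 2 and a 2.8-fold lower number (0.45 log units; beyond the scatter) from compound 3 to compound 4, 2.5-fold (0.40 log units) apart, within the scatter of two such steps. The change on the chain carbon bound to a sulfur, within the scatter on the shorter amino chain, now gives a step beyond it, a 4.3-fold higher number from compound 2 to compound 4 (0.63 log units; beyond the scatter), yet that pair of steps also cannot be told apart: the same change on two cores in this assay, a 1.7-fold higher number (0.23 log units; within the scatter) from compound 1 to compound 3 and a 4.3-fold higher number (0.63 log units; beyond the scatter) from compound 2 to compound 4, 2.5-fold (0.40 log units) apart, within the scatter of two such steps.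

On these data alone, whether a longer chain such as hexyl would lower the number further remains open. So does the effect of placing a hydroxyl or an amine at the end of the chain.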